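Series notes: side-chain variation at the hydroxy acyl group

The source may hold more compounds than are shown below. What is called first, only, known or untested is meant among the compounds shown, and "the series" means these compounds.

Measured so far:
- compound 1, `COC(C)(C)[C@@H](O)C(=O)N1[C@H](C(=O)NCc2cc(Cl)ccc2-n2cnnn2)C[C@@H]2C[C@@H]21`, 1000 nM
- compound 2, `COC(C)(C)[C@@H](O)C(=O)N1N=CC[C@H]1C(=O)NCc1cc(Cl)ccc1-n1cnnn1`, 3700 nM
- compound 3, `CC(C)(C)[C@@H](O)C(=O)N1OCC[C@H]1C(=O)NCc1cc(Cl)ccc1-n1cnnn1`, 1600 nM

All three were run in a functional assay on a cell-free system (plasma, Homo sapiens), with a stated time of 3 min; on this read-out lower numbers stand for stronger inhibition and higher numbers for weaker inhibition. Compound 2 gives the highest number of the three; compound 3 and compound 1 both sit at lower numbers, and both of those gaps lie beyond the usual scatter of repeated measurements, so compound 2 is the weakest inhibitor of the trio on this read-out.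

Compound 4, `O=C(NCc1cc(Cl)ccc1-n1cnnn1)[C@@H]1CC=NN1C(=O)[C@H](O)Cc1ccccc1`, has not yet been measured. Relative to compound 2 the change is benzyl in place of 1-methoxy-1-methylethyl on a saturated chain carbon bound to a carbonyl carbon and an oxygen on a saturated carbon. The shared core, the amide and the hydroxyl are untouched; only the group on the carbon bearing the hydroxyl is exchanged.

Going by the values given here, no pair of measured compounds isolates this particular exchange, so the direction of the step is open. The expectation is a small step, a 1.2-fold lower number from compound 2 to compound 4 (0.09 log units; within the scatter), with the number for compound 4 staying in the range of the measured set rather than moving far in either direction. Compound 4 is estimated at 3000 nM, within 1000 nM to 10000 nM.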

Compound 4, half-maximal inhibitory concentration: 1400 nM
Estimate against measurement, compound 4: 2.1-fold (0.33 log units) above, and the stated range covers the measured number.
By their numbers in this assay, from the lowest: compounds 1, 4 and 3 (each within the scatter of the next); then compound 2.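

In this assay, going by these compounds alone, benzyl in place of 1-methoxy-1-methylethyl on a saturated chain carbon bound to a carbonyl carbon and an oxygen on a saturated carbon gives a 2.6-fold lower number from compound 2 to compound 4 (0.42 log units; beyond the scatter), the first step that changes one place only. In this pair, the position takes a six-membered aromatic ring of carbon only without loss of inhibition, and the oxygen of the leaving group is not needed to reach the lower number. Nothing measured on these compounds accounts for the step.

As far as these compounds go, whether the aromatic ring itself matters remains open, and a cyclohexylmethyl group, a 2-phenylethyl chain or an amine on the phenyl ring would test this. Also open, from the compounds shown here alone, is whether the same exchange carries over to the cores of compound 1 and compound 3.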